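Removing a methyl from a whole-animal activator

The compounds below may be only part of what the source reports. "The series", "measured", "known", "first", "only" and "open" are said of these compounds alone.

Compound 1, `CCCCOc1nc(N)c2[nH]c(=O)n(Cc3ccccc3)c2n1`: 0.1 mg/kg
Compound 2, `Cc1nc(N)c2nc(O)n(Cc3ccccc3)c2n1`: 3 mg/kg

Among the measured compounds shown here, compound 2 stands at the highest of these two numbers in a functional assay on the whole organism for activation, with Mus musculus as the target; a higher number here means that more compound is needed for the effect, a lower number that less compound is needed; compound 1, its only neighbour, sits at a far lower number, a gap well beyond the scatter. Compound 3, `Nc1ncnc2c1nc(O)n2Cc1ccccc1`, differs from compound 2 by hydrogen in place of methyl on an aromatic carbon. For the measured compounds named here, no step between measured compounds is available, so no size can be read from the data. Since the smaller group left on the core is expected to weaken the effect, the expected step is a 3.3-fold higher number from compound 2 to compound 3 (0.52 log units; beyond the scatter), toward a higher number. Compound 3 is therefore estimated at 10 mg/kg, within a range from 2 mg/kg to 50 mg/kg.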

Compound 3, minimum effective dose: 30 mg/kg
Beside the measured number, compound 3's estimate is 3.0-fold (0.48 log units) below it, within the range that was stated.
By their numbers in this assay, from the lowest: compound 1; then compound 2; then compound 3.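

Removing the methyl from the aromatic carbon between two ring nitrogen atoms gives a 10-fold higher number from compound 2 to compound 3 (1.00 log units; beyond the scatter) in this assay. Among the compounds shown here, this is the first size read from a single change at this position, and it shows that even one carbon there separates compound 2 from compound 3 by more than the usual scatter. Nothing measured here explains the step. Still open, as far as these compounds go, is whether an ethyl group on this carbon would lower the number further, and whether an amine there would match methyl or hydrogen.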